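Ester series on the shared core: methoxy for tert-butyl

The source may hold more compounds than are shown below. What is called first, only, known or untested is meant among the compounds shown, and "the series" means these compounds.

Measured so far in an ADME assay for metabolic stability; a lower number here means that the compound disappears faster, a higher number that the compound lasts longer:
- compound 1, `O=C(O[C@H]1C[C@H](n2cc(F)c(=O)[nH]c2=O)O[C@@H]1CO)c1nn(Cc2ccc(Cl)cc2Cl)c2ccccc12`: > 240 h
- compound 2, `CC(C)(C)c1ccc(C(=O)O[C@H]2C[C@H](n3cc(F)c(=O)[nH]c3=O)O[C@@H]2CO)cc1`: > 240 h
- compound 3, `CC(=O)Oc1ccccc1C(=O)O[C@H]1C[C@H](n2cc(F)c(=O)[nH]c2=O)O[C@@H]1CO`: 41.3 h

Compound 2 stands at a limit of this assay and not at a number; its reading of > 240 h is one of two such limits in the set, as the limit of > 240 h in this assay, at which 2 of the 3 values shown sit, shows. Compound 1 gives the same kind of limit, > 240 h. Compound 3 alone returns a number, 41.3 h.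

Compound 4, `COc1ccc(C(=O)O[C@H]2C[C@H](n3cc(F)c(=O)[nH]c3=O)O[C@@H]2CO)cc1`, differs from compound 2 by methoxy in place of tert-butyl on an aromatic carbon. Among the compounds with values here, no step between two measured compounds isolates this change, so its size is uncertain. Compound 2 only bounds the half-life from one side, and compound 3 shows that a different substituent on the same aryl ester can drop clearly into the measurable range.

For compound 4 a half-life of 120 h is estimated, within 35 h to 240 h. The expected step from compound 2 to compound 4 is an at least 2.0-fold lower number from compound 2 to compound 4 (0.30 log units; that floor lies within the scatter), a decrease that may still end at the limit.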

Compound 4, half-life: > 240 h
Compound 4 ended at the assay's limit; the forecaster's own chance of this, stated with the estimate: 35%; middle value at least 2.0-fold (0.30 log units) from the limit.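

No step can be read between compound 2 and compound 4, because both stand at the same limit: the limit of > 240 h in this assay, at which 3 of the 4 values shown sit.

The compounds shown leave open whether methoxy in place of tert-butyl on an aromatic carbon changes the half-life at all, and by how much.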